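Two ring stereocentres inverted: lipophilicity notes

The source may hold more compounds than are shown below. What is called first, only, known or untested is meant among the compounds shown, and "the series" means these compounds.

Measured so far:
compound 1 `COC(=O)N[C@H](C(=O)N1CCC[C@H]1C(=O)Nc1ccc([C@@H]2CC[C@@H](c3ccc(NC(=O)[C@@H]4CCCN4C(=O)[C@@H](NC(=O)OC)[C@H]4CCOC4)cc3)N2c2ccc(F)cc2)cc1)[C@H]1CCOC1` — 3.2
compound 2 `COC(=O)N[C@H](C(=O)N1CCC[C@H]1C(=O)Nc1ccc([C@@H]2CC[C@@H](c3ccc(NC(=O)[C@@H]4CCCN4C(=O)[C@@H](NC(=O)OC)C(C)C)cc3)N2c2ccc(C(F)(F)F)cc2)cc1)C(C)C` — 4.8

In a physicochemical assay for lipophilicity, read by HPLC, at pH 7.4 (a lower number here means a more polar compound, a higher number a more lipophilic compound), compound 1 gives 3.2, the lower of the two numbers. In this assay compound 2 gives 4.8, a number beyond the scatter higher than that of compound 1. Among the measured compounds shown here, compound 1 and compound 2 differ in several places at once, so no single step between them can be read.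

Compound 3 `COC(=O)N[C@H](C(=O)N1CCC[C@H]1C(=O)Nc1ccc([C@H]2CC[C@H](c3ccc(NC(=O)[C@@H]4CCCN4C(=O)[C@@H](NC(=O)OC)[C@H]4CCOC4)cc3)N2c2ccc(F)cc2)cc1)[C@H]1CCOC1` has not been measured. (the two compounds have the same atoms and bonds and differ only in configuration as drawn: 2 of 8 stereo elements differ; a stereocentre at a saturated ring carbon is drawn S in compound 1 and R in compound 3; a stereocentre at a saturated ring carbon is drawn S in compound 1 and R in compound 3). For the measured compounds named here, no measured pair in the set differs only in configuration, so the expectation for compound 3 rests on compound 1 alone. Because compound 1 stands at 3.2 and compound 3 carries the same atoms and bonds, the step from compound 1 to compound 3 in this assay is expected to stay within the scatter, with no set direction: no change at the digits printed from compound 1 to compound 3 (within the scatter). Compound 3 is therefore estimated at 3.2, with a range of 2.8 to 3.6.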

Compound 3, distribution coefficient: 3.2
Compound 3: middle estimate and measured number agree at the digits printed; measured number inside the range.
By their numbers in this assay, from the lowest: compounds 1 and 3 (each within the scatter of the next); then compound 2.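

In this assay, inverting the two stereocentres at saturated ring carbons gives no change at the digits printed from compound 1 to compound 3 (within the scatter). Among the compounds shown here, this is the first reading of configuration at this position on its own, as the steps involving compound 2, which differs from the other compounds in several places, cannot be read: the fact that compounds 1 and 3 differ only in the configuration as drawn For this one pair, then, this assay does not separate the two drawn configurations, and the reading applies only to these two compounds and this inversion.

The pair does not show what inverting only one of the two stereocentres would do, nor whether inverting both would read the same way in a compound without the two rings that compounds 1 and 3 share at their ends. It also leaves open whether the same would hold with an amine or a carboxylic acid on the shared core.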